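Swapping the aryl on the ring nitrogen: compound 3

The source may report more compounds than this note shows. Statements on the series, on what has been measured and on what is new or still open speak of the compounds shown alone.

Measured compounds in a functional assay on HT-29 cells (Homo sapiens) for cytotoxicity, read by MTT assay, with a stated time of 72 h; on this read-out lower numbers stand for stronger inhibition and higher numbers for weaker inhibition:
- compound 1 `COc1ccc(-c2cc(/N=C3\SCC(=O)N3c3cccc(OC)c3)cs2)cc1`: 11700 nM
- compound 2 `COc1cccc(N2C(=O)CS/C2=N\c2csc(-c3ccc(Cl)cc3)c2)c1`: 24600 nM

Compound 2 stands at the highest of the two numbers; compound 1 sits at the other end, and the change from compound 1 to compound 2 was a 2.1-fold higher number from compound 1 to compound 2 (0.32 log units; beyond the scatter), a swap on the aromatic carbon at the far side of the shared core.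

Compound 3 `Cc1ccc(N2C(=O)CS/C2=N\c2csc(-c3ccc(Cl)cc3)c2)cc1` differs from compound 2 elsewhere: 4-methylphenyl in place of 3-methoxyphenyl on an amide-type nitrogen in a ring. Among the compounds with values here, no measured step touches this amide-type nitrogen, so the one known step offers no guide to it. With nothing to suggest a shift, the expectation is a step of no size beyond the scatter, a 1.0-fold higher number from compound 2 to compound 3 (0.01 log units; within the scatter). Compound 3 is therefore expected to give about 25000 nM in this assay, with a plausible range from 10000 nM to 60000 nM.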

Compound 3, half-maximal inhibitory concentration: 28900 nM
The estimate for compound 3 lay 1.2-fold (0.06 log units) below the measured number; the range from low to high includes it.
By their numbers in this assay, from the lowest: compound 1; then compounds 2 and 3 (each within the scatter of the next).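

Within the data shown here, this is the first step at the amide-type nitrogen of the five-membered ring. In this assay the change to 4-methylphenyl from 3-methoxyphenyl gives a 1.2-fold higher number from compound 2 to compound 3 (0.07 log units; within the scatter) and so leaves compound 2 and compound 3 indistinguishable, even though an aryl group with an oxygen atom gives way to one of carbon only. No measurement here explains why this step stays so small.

Among these compounds, this single pair covers only two substituted phenyl groups, so it remains open whether a very different group on this nitrogen, such as a plain methyl, a longer alkyl chain, or a phenyl ring carrying a carboxylic acid or an amine, would shift the number beyond the scatter. From the compounds shown here alone, it is also open whether this swap would behave the same way with the methoxy group of compound 1 in place of the chloro group at the far side of the shared core.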